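Ether-chain extension on the shared core: compound 4

The compounds below may be only part of what the source reports. "The series", "measured", "known", "first", "only" and "open" are said of these compounds alone.

Measured compounds:
compound 1 `CC(C)=CCC1Cc2c(O)cc(=O)n(CCCO)c2CC1(C)C` gives 25.6% in a functional assay on PANC-1 cells (Homo sapiens) for inhibition, read by MTT assay, with a stated time of 24 h, tested at 10 uM; on this read-out lower numbers stand for less inhibition and higher numbers for more inhibition at the one concentration tested (going by the name of the read-out)
compound 2 `CC(C)=CCC/C(C)=C/CC1Cc2c(O)cc(=O)n(CCCO)c2CC1(C)C` gives 28.7% in this assay
compound 3 `CC(C)=CCC1Cc2c(OCCCNS(=O)(=O)c3ccc(Br)cc3)cc(=O)n(CCCO)c2CC1(C)C` gives 19.5% in this assay

Compound 2 gives the largest of the three numbers, yet compound 1 and compound 3 both lie within the scatter of it, so no ranking among the three can be claimed. Among the measured compounds shown here, the one step between neighbours is a number 3.1 percentage points higher from compound 1 to compound 2 (within the scatter), and it concerns a chain carbon, not the aromatic oxygen.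

Compound 4 `CC(C)=CCC/C(C)=C/CC1Cc2c(OCCCOc3ccc(Cl)cc3)cc(=O)n(CCCO)c2CC1(C)C` differs from compound 2 in one place: 3-(4-chlorophenoxy)propyl in place of hydrogen on an oxygen on an aromatic ring. For the measured compounds named here, no measured step covers this change. Compound 1 carries hydrogen on that oxygen and gives 25.6%, while compound 3 carries a different group on the same oxygen and gives 19.5%; these two values differ by less than the scatter, which is the only hint available on substitution at that oxygen.

The step expected from compound 2 to compound 4 is therefore a number 4.7 percentage points lower from compound 2 to compound 4 (within the scatter), none beyond the scatter. Compound 4 is estimated at 24%, with a range from 10% to 40%.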

Compound 4, a percentage reported as inhibition, at one concentration (the size of the read-out at that concentration, not a potency): 25.2%
Beside the measured number, compound 4's estimate is 1.2 percentage points below it, within the range that was stated.
By their numbers in this assay, from the lowest: compounds 3, 4, 1 and 2 (each within the scatter of the next).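

Among the compounds shown here, replacing hydrogen with 3-(4-chlorophenoxy)propyl on the oxygen on an aromatic ring gives, in this assay, a number 3.5 percentage points lower from compound 2 to compound 4 (within the scatter), the first measured step at this position. This oxygen therefore carries an entering group of 11 heavy atoms, including one six-membered aromatic ring, with no shift beyond the scatter, so hydroxy to 3-(4-chlorophenoxy)propoxy leaves this read-out unresolved from the parent compound 2. No accompanying data bear on this result.

Still open, from the compounds shown here alone, is whether an amine or a carboxylic acid at the end of the propyl chain, or a longer chain on the same oxygen, would move the number beyond the scatter. Going by these compounds, with a single concentration behind each number, potency also remains open for the whole series.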